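The source may report more compounds than this note shows. Statements on the series, on what has been measured and on what is new or still open speak of the compounds shown alone.

In a functional assay on HL-60 cells (Homo sapiens) for cytotoxicity, read by luminescence and CellTiter-Glo, with a stated time of 3 days (a higher number here means a weaker inhibitor, a lower number a stronger inhibitor), compound 1 (`O=C(Nc1ccc(C(F)(F)F)cc1)c1cc(Cl)ccc1O`) gives 510 nM. Going by the values given here, its only measured neighbour, compound 2 (`O=C(Nc1ccc(C(F)(F)F)cc1)c1cc(F)ccc1O`), gives 490 nM, so the two numbers stand within the scatter of each other. Among the compounds with values here, the one measured step, a 1.0-fold lower number from compound 1 to compound 2 (0.02 log units; within the scatter), is fluoro in place of chloro on an aromatic carbon. Compound 3 (`O=C(Nc1ccc(C(F)(F)F)cc1)c1cc(Cl)c(-c2ccccc2)cc1O`) keeps the core of compound 1 but carries phenyl in place of hydrogen on an aromatic carbon, ortho to a chloro group, meta to a hydroxy group and para to a large group: phenyl in place of hydrogen on an aromatic carbon. The measured step swaps one single atom for another and adds no ring, so it is only a weak guide here. With no evidence for a direction, no shift beyond the scatter is expected in this assay. The expected step is a 1.3-fold lower number from compound 1 to compound 3 (0.11 log units; within the scatter). Compound 3 is estimated at 400 nM, with an expected range from 120 nM to 1300 nM.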

Compound 3, half-maximal inhibitory concentration: 490 nM
The estimate for compound 3 lay 1.2-fold (0.09 log units) below the measured number; low and high end bracket the measured number.
By their numbers in this assay, from the lowest: compounds 2, 3 and 1 (each within the scatter of the next).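

Compound 3 shows that this position, ortho to a chloro group, meta to a hydroxy group and para to a large group, accepts a whole added phenyl ring, not just the exchange of one single atom for another seen earlier. In this assay the change gives a 1.0-fold lower number from compound 1 to compound 3 (0.02 log units; within the scatter), so the 6 heavy atoms of the new ring leave the number within the scatter of that of compound 1. No measurement at hand accounts for this tolerance.

From the compounds shown here alone, it remains open whether the position would tolerate a phenyl ring bearing a carboxylic acid or an amine, or a longer chain such as benzyl. Going by these compounds, it is equally open whether a pyridine ring in place of the phenyl would give a number beyond the scatter.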